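Changing the Aryl Group: An Expectation for Compound 4

The source may report more compounds than this note shows. Statements on the series, on what has been measured and on what is new or still open speak of the compounds shown alone.

Measured compounds:
compound 1 `CCCCCCCCc1ccc(OCC(=O)Cn2nnc(-c3ccccc3Cl)n2)cc1` — 32 nM
compound 2 `CCCCCCCCc1ccc(OCC(=O)Cn2nnc(-c3cccs3)n2)cc1` — 32 nM
compound 3 `CCCCCCCCc1ccc(OCC(=O)Cn2nnc(CCC(=O)O)n2)cc1` — 30 nM

In an assay on microsomes from brain for inhibition of Fatty-acid amide hydrolase 1 (Rattus norvegicus), read by fluorescence and HPLC, with a stated time of 60 min (on this read-out higher numbers stand for weaker inhibition and lower numbers for stronger inhibition), compound 1 gives 32 nM, level with compound 2 at the digits shown and together with it the highest of the three numbers; compound 3 is the furthest away, yet every gap lies within the scatter. Compound 4 `CCCCCCCCc1ccc(OCC(=O)Cn2nnc(-c3ccc(C(=O)O)cc3)n2)cc1` differs from compound 1 in one place: 4-carboxyphenyl in place of 2-chlorophenyl on an aromatic carbon. Among the measured compounds shown here, the steps that bear on this are no change at the digits printed from compound 1 to compound 2 (within the scatter) and a 1.1-fold lower number from compound 1 to compound 3 (0.03 log units; within the scatter), and also a 1.1-fold lower number from compound 2 to compound 3 (0.03 log units; within the scatter): three very different groups at this position leave the number unmoved. The expectation is therefore no change at the digits printed from compound 1 to compound 4 (within the scatter), no step beyond the scatter. Compound 4 is estimated at 32 nM, within a range from 14 nM to 75 nM.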

Compound 4, half-maximal inhibitory concentration: 90 nM
Estimate against measurement, compound 4: 2.8-fold (0.45 log units) below; measured number above the stated range.
By their numbers in this assay, from the lowest: compounds 3, 1 and 2 (each within the scatter of the next); then compound 4.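

This position does not accept every group equally: 4-carboxyphenyl brings a 2.8-fold higher number from compound 1 to compound 4 (0.45 log units; beyond the scatter) and a 2.8-fold higher number from compound 2 to compound 4 (0.45 log units; beyond the scatter) and also a 3.0-fold higher number from compound 3 to compound 4 (0.48 log units; beyond the scatter) in this read-out, each a modest step towards weaker inhibition. Compound 3 also carries a carboxylic acid, on its 2-carboxyethyl group, so the acid alone does not go with the higher number. Nothing measured here gives a reason for the shift. The compounds shown leave open whether the higher number follows the phenyl ring that carries the acid or the combination of ring and acid. A phenyl group without the acid, or a longer chain ending in a carboxylic acid, would bear on that question.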